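The source may report more compounds than this note shows. Statements on the series, on what has been measured and on what is new or still open speak of the compounds shown alone.

Compound 2 `CC1CCCN(Cc2c(-c3nnc(SC(C)C)n3-c3ccccc3)n(C)c3ccc(F)cc23)C1` gives 6.18 in a physicochemical assay for lipophilicity; a higher number here means a more lipophilic compound, a lower number a more polar compound. Among the three measured compounds it holds the highest of the numbers, but only narrowly: compound 1 `CC1CCCN(Cc2c(-c3nnc(SC(C)C)n3-c3ccccc3)n(C)c3ccccc23)C1` gives 6.03, and the step of a number 0.15 log units higher from compound 1 to compound 2 (within the scatter) lies within the scatter, so these two cannot be told apart. Compound 3 `CC(C)Sc1nnc(-c2c(CNCC3CC3)c3ccccc3n2C)n1-c1ccccc1` gives 5.24 and is the furthest away; the step of a number 0.79 log units lower from compound 1 to compound 3 (beyond the scatter) lies beyond the scatter.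

Compound 4 `CC1CCN(Cc2c(-c3nnc(SC(C)C)n3-c3ccccc3)n(C)c3ccc(F)cc23)CC1` has not yet been measured. It differs from compound 2 in one place: 4-methylpiperidin-1-yl in place of 3-methylpiperidin-1-yl on a saturated chain carbon bound to an aromatic carbon. Among the compounds with values here, no measured step shows this exact change. The step from compound 1 to compound 3 replaces the whole amine on that saturated chain carbon with a different one and is modest, while the step from compound 1 to compound 2 concerns a fluoro on an aromatic carbon and stays within the scatter. Compound 2 and compound 4 have the same atoms, joined differently, and the step of no change at the digits printed from compound 2 to compound 4 (within the scatter) is expected to be none beyond the scatter. Compound 4 is therefore estimated at 6.18, in a range from 5.88 to 6.48.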

Compound 4, partition coefficient: 6.12
Compound 4: the middle estimate sits 0.06 log units above what was measured; measured number inside the range.
By their numbers in this assay, from the lowest: compound 3; then compounds 1, 4 and 2 (each within the scatter of the next).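

Putting 4-methylpiperidin-1-yl in place of 3-methylpiperidin-1-yl gives a number 0.06 log units lower from compound 2 to compound 4 (within the scatter), so this assay cannot tell these two compounds with the same atoms apart. Within the data shown here, the only earlier change of amine at this saturated chain carbon was larger, with a number 0.79 log units lower from compound 1 to compound 3 (beyond the scatter), so this result adds that not every change of amine here shifts the number beyond the scatter. Nothing available explains why these amines behave as they do.

The compounds shown leave open how the number would respond to a morpholine, a plain piperidine without the methyl, or an open-chain amine such as diethylamino on that same carbon. They also leave open whether 2-methylpiperidin-1-yl would stay as close to compound 2 as 4-methylpiperidin-1-yl does.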